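A few compounds are considered here, and "the series" means these few. Any claim that something is new, unique, unknown or untested is made for them only; others in the source may bear on it.

Working notes on the series.

Compound 2, `CCOC(=O)c1oc2nc(-c3ccccc3)cc(C(F)(F)F)c2c1N`, carries an ethoxycarbonyl on the shared core. In an ADME assay on Huh-7 cells (Homo sapiens) for cytotoxicity, read by MTT assay, with a stated time of 72 h (a higher number here means that more compound is tolerated, a lower number that less compound is tolerated), compound 2 gives only the assay limit, > 20000 nM, so no number is known for it. Compound 1, `NC(=O)c1sc2nc(-c3ccccc3)cc(C(F)(F)F)c2c1N`, the primary amide analogue on a related core, in this assay likewise stops at the limit, > 20000 nM. Compound 3, `CCOC(=O)c1oc2nc(-c3cccs3)cc(C(F)(F)F)c2c1N`, in this assay also reaches only the limit, > 20000 nM. Within the data shown here, the one step between neighbours, a step that the two limits leave unreadable from compound 2 to compound 3, is therefore unreadable. What holds the series together is the limit of > 20000 nM in this assay, at which 3 of the 3 values shown sit.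

Compound 4, `Nc1c(C(=O)NCc2cccs2)oc2nc(-c3ccccc3)cc(C(F)(F)F)c12`, differs from compound 2 by ((thiophen-2-yl)methyl)amino in place of ethoxy on a carbonyl carbon, in words ((thiophen-2-yl)methyl)amino in place of ethoxy on a carbonyl carbon. Among the measured compounds shown here, no measured step covers this change; the only step in the set, from compound 2 to compound 3, is unreadable. On the numbers shown, no step beyond the scatter is expected, and the estimated step that the limit leaves unreadable from compound 2 to compound 4 reflects that compound 4 is most likely to sit at the limit as well. Compound 4 is expected at 25000 nM in this assay, with a range from 10000 nM to 60000 nM.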

Compound 4, half-maximal cytotoxic concentration: > 20000 nM
Compound 4 was reported as a limit; the forecaster's own chance of this, stated with the estimate: 75%; the middle value is on the limit's open side.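

In this assay compound 4 gives only a limit of the assay, > 20000 nM. No step can be read from compound 2 to compound 4, and the series stays at a single limit: the limit of > 20000 nM in this assay, at which 4 of the 4 values shown sit. The compounds shown leave open where the half-maximal cytotoxic concentration of each compound lies, and so whether any structural change alters it.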